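Ester exchange at the high end of the series

The source may report more compounds than this note shows. Statements on the series, on what has been measured and on what is new or still open speak of the compounds shown alone.

Measured so far in a functional assay on SEM cells (Homo sapiens) for cytotoxicity, with a stated time of 72 h; a lower number here means that less compound is needed, a higher number that more compound is needed for the effect
compound 1 (`COc1ccc(/C=C/[C@@](C)(/C=C/c2ccc(O)c(/C=C/C#N)c2)CCC=C(C)C)cc1`) - 4540 nM
compound 2 (`CCOC(=O)/C(C)=C/c1cc(/C=C/[C@](C)(/C=C/c2ccc(OC)cc2)CCC=C(C)C)ccc1O`) - > 36600 nM (limit)

Compound 2 gives > 36600 nM as a limit of the assay and not a number. For the measured compounds named here, the one measured step is an at least 8.0-fold higher number from compound 1 to compound 2 (0.90 log units; beyond the scatter) and puts 2-(ethoxycarbonyl)prop-1-en-1-yl in place of 2-cyanoethenyl.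

Compound 3 (`COc1ccc(/C=C/[C@@](C)(/C=C/c2ccc(O)c(/C=C/C(=O)OC(C)(C)C)c2)CCC=C(C)C)cc1`) has not been measured. Its difference from compound 2 is 2-(tert-butoxycarbonyl)ethenyl in place of 2-(ethoxycarbonyl)prop-1-en-1-yl on an aromatic carbon with 2-(tert-butoxycarbonyl)ethenyl in place of 2-(ethoxycarbonyl)prop-1-en-1-yl, ortho to a hydroxy group. Going by the values given here, no measured step covers an exchange of one ester for another. Compound 3 keeps an ester rather than the 2-cyanoethenyl of compound 1, so the expectation leans on an at least 8.0-fold higher number from compound 1 to compound 2 (0.90 log units; beyond the scatter) and stays near compound 2. In this assay a small step to a lower number is expected, possibly none beyond the scatter. The expected step is an at least 1.3-fold lower number from compound 2 to compound 3 (0.11 log units; that floor lies within the scatter) and it may again end in a limit. For compound 3 the estimated value is 28000 nM with an expected range from 9000 nM to 60000 nM in this estimate.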

Compound 3, half-maximal effective concentration: > 36600 nM
Compound 3 gave a limit, no number (the forecaster's own chance of this, stated with the estimate: 45%); at least 1.3-fold (0.11 log units) between middle value and limit.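

At this position, on an aromatic carbon ortho to a hydroxy group, tert-butoxycarbonyl in place of cyano on the ethenyl chain gives an at least 8.0-fold higher number from compound 1 to compound 3 (0.90 log units; beyond the scatter) in this assay. The chain of compound 3 remains an ethenyl, so the loss seen with compound 2 does not require its 2-(ethoxycarbonyl)prop-1-en-1-yl chain and appears with a second ester in place of the nitrile. The two esters cannot be ranked, because compound 2 and compound 3 both end in a limit of the assay rather than a number: the limit of > 36600 nM in this assay, at which 2 of the 3 values shown sit.

As far as these compounds go, whether any ester at this position gives a readable value remains open, as does the size of the full step from the nitrile. Also open, from the compounds shown here alone, is how a carboxylic acid or a primary amide at the end of the ethenyl chain would compare with the nitrile of compound 1.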